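Trimethoxyphenyl in place of chlorophenyl on the pyrazole series

The compounds below may be only part of what the source reports. "The series", "measured", "known", "first", "only" and "open" are said of these compounds alone.

Three compounds of the series have numbers in an ADME assay on HaCaT cells (Homo sapiens) for antiproliferative activity, read by MTT assay, with a stated time of 48 h; a lower number here means a stronger inhibitor, a higher number a weaker inhibitor. Compound 1 `O=C(/C=C\Nc1ccc(Cl)cc1)c1cn(-c2ccccc2)nc1-c1ccccc1` gives 28400 nM in this assay. Compound 2 `O=C(/C=C\Nc1ccc(C(F)(F)F)cc1)c1cn(-c2ccccc2)nc1-c1ccc(F)cc1` reaches only a limit of this assay, > 50000 nM, which is the limit of > 50000 nM in this assay, at which 1 of the 3 values shown sits. Compound 3 `COc1cc(N/C=C\C(=O)c2cn(-c3ccccc3)nc2-c2ccc(Cl)cc2)cc(OC)c1OC` gives 46600 nM in this assay, and this number and the number of compound 1 lie within the scatter of each other, so the two are not told apart. The remaining entry for compound 2 is a limit of this assay. All three therefore sit at the weak end of this assay.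

Compound 4 `COc1cc(N/C=C\C(=O)c2cn(-c3ccccc3)nc2-c2cc(OC)c(OC)c(OC)c2)cc(OC)c1OC` is not yet measured. It differs from compound 3 in one place: 3,4,5-trimethoxyphenyl in place of 4-chlorophenyl on an aromatic carbon. Among the measured compounds shown here, no measured pair in the set shares this exact change, and the measured numbers give no ground for a step beyond the scatter in either direction. The step from compound 3 to compound 4 is expected to be about a 1.0-fold higher number from compound 3 to compound 4 (0.01 log units; within the scatter), none beyond the scatter. Compound 4 is accordingly estimated at 48000 nM in this assay, with a range from 20000 nM to 120000 nM, and a sizeable chance that this assay reports only a limit for it.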

Compound 4, half-maximal inhibitory concentration: 20900 nM
Estimate against measurement, compound 4: 2.3-fold (0.36 log units) above; measured number inside the range.
By their numbers in this assay, from the lowest: compounds 4, 1 and 3 (each within the scatter of the next, the first and the last beyond it). At a limit, above all of these: compound 2.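

In this assay, among the compounds shown here, the aryl group on an aromatic carbon of a five-membered aromatic ring with 2 nitrogen is the first place where a single change can be read: 3,4,5-trimethoxyphenyl in place of 4-chlorophenyl gives a 2.2-fold lower number from compound 3 to compound 4 (0.35 log units; beyond the scatter). This position therefore responds to the exchange, which is modest in size and adds 3 hydrogen-bond acceptors to a group that had 0, and which moves the number towards stronger inhibition, although compound 4 at 20900 nM remains a weak inhibitor in absolute terms. No measured property of these compounds bears on the reason for the step, so the change in the group cannot be tied to any cause.

Going by these compounds, the step rests on a single pair, so it remains open whether it carries over when the rest of the structure differs from that shared by compound 3 and compound 4. Also open, on these data alone, is how this position would respond to a phenyl ring bearing a single methoxy group, an amine or a carboxylic acid, and whether any such group would bring the number clear of the weak end of the range.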